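Swapping a ring chloro for piperidin-1-yl

The compounds below may be only part of what the source reports. "The series", "measured", "known", "first", "only" and "open" are said of these compounds alone.

Compound 1 `CCCCOC1OC(=O)C(Cl)=C1Cl`: 22500 nM
Compound 2 `CC(C)(C)COC1OC(=O)C(Cl)=C1Cl`: 7700 nM
Compound 3 `CC(C)(C)OC1OC(=O)C(Cl)=C1Cl`: 14000 nM

In a functional assay on A549 cells (Homo sapiens) for cytotoxicity, read by MTT assay, with a stated time of 72 h (a higher number here means a weaker inhibitor, a lower number a stronger inhibitor), compound 1 gives 22500 nM, which places it at the upper end of the three numbers. Compound 4 `CCCCOC1OC(=O)C(Cl)=C1N1CCCCC1` keeps the rest of compound 1 but carries piperidin-1-yl in place of chloro on a double-bonded ring carbon. The two measured steps, a 1.6-fold lower number from compound 1 to compound 3 (0.21 log units; within the scatter) and a 2.9-fold lower number from compound 1 to compound 2 (0.47 log units; beyond the scatter), alter only the chain on oxygen, so neither speaks directly to this ring carbon. With no measured change at this place, the guide is weak, and a modest move toward a higher number is expected, namely a 2.2-fold higher number from compound 1 to compound 4 (0.35 log units; beyond the scatter). For compound 4 the estimated value is 50000 nM, with an expected range of 14000 nM to 170000 nM.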

Compound 4, half-maximal inhibitory concentration: 93300 nM
The estimate for compound 4 lay 1.9-fold (0.27 log units) below the measured number; low and high end bracket the measured number.
By their numbers in this assay, from the lowest: compounds 2, 3 and 1 (each within the scatter of the next, the first and the last beyond it); then compound 4.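

Going by these compounds alone, earlier steps changed only the chain on oxygen, whereas this double-bonded ring carbon now gives a first reading in this assay with a 4.1-fold higher number from compound 1 to compound 4 (0.62 log units; beyond the scatter) when piperidin-1-yl replaces chloro. This step lies beyond the scatter and marks compound 4 as the weaker inhibitor, so replacing chloro here is not neutral. Nothing available explains the shift.

On these data alone, whether diethylamino or morpholin-4-yl at this carbon would move the number the same way remains open. So does whether piperidin-1-yl would have a similar effect on compound 2 or compound 3.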